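Swapping cyclopropyl for isopropyl on the amide of compound 2

This account rests on a few compounds, and the source may have more. Where it says the series, first, only, none or still open, it means among the compounds named here.

Measured compounds:
Compound 1 `CCn1cc(-c2ccc(F)cc2)c(=O)c2c(Nc3ccc(Oc4ccnc(NC(=O)C5CC5)c4)c(F)c3)nccc21` gives 15.8% in a functional assay on HT-29 cells (Homo sapiens) for antiproliferative activity, read by MTT assay, with a stated time of 72 h, tested at 10 uM; on this read-out higher numbers stand for more inhibition at the one concentration tested (going by the name of the read-out) and lower numbers for less inhibition.
Compound 2 `O=C(Nc1cc(Oc2ccc(Nc3nccc4[nH]cc(-c5ccc(F)cc5)c(=O)c34)cc2F)ccn1)C1CC1` gives 25.5% in this assay.

Compound 2 and compound 1 differ only by hydrogen in place of ethyl on an aromatic nitrogen, and the step of a number 9.7 percentage points higher from compound 1 to compound 2 (within the scatter) lies within the scatter, so neither compound can be placed above the other on these numbers.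

Compound 3 `CC(C)C(=O)Nc1cc(Oc2ccc(Nc3nccc4[nH]cc(-c5ccc(F)cc5)c(=O)c34)cc2F)ccn1` has not yet been measured. It differs from compound 2 by isopropyl in place of cyclopropyl on a carbonyl carbon. Going by the values given here, no measured step touches this part of the molecule: the single step between compound 1 and compound 2 concerns the aromatic nitrogen and says nothing about the cyclopropylcarbonyl group. Among the compounds with values here, with no bearing step in hand and the only known step small, a step beyond the scatter in this assay is not expected in either direction.

Compound 3 is therefore estimated at 24%, within 8% to 42%, which means an expected step of a number 1.5 percentage points lower from compound 2 to compound 3 (within the scatter).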

Compound 3, a percentage reported as inhibition, at one concentration (the size of the read-out at that concentration, not a potency): 83.4%
Estimate against measurement, compound 3: 59.4 percentage points below; the whole stated range lies below it.
By their numbers in this assay, from the lowest: compounds 1 and 2 (each within the scatter of the next); then compound 3.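

In this assay, going by these compounds alone, the position on the carbonyl carbon proves far more responsive than the aromatic nitrogen: isopropyl in place of cyclopropyl gives a number 57.9 percentage points higher from compound 2 to compound 3 (beyond the scatter), the only single change so far that lies beyond the scatter. The two groups hold the same count of heavy atoms and the same absence of hydrogen-bond donors and acceptors, so opening the three-membered ring, with no change in those counts, is enough to produce a step of this size. Nothing at hand says why the step is so large.

From the compounds shown here alone, whether a tert-butyl, a longer chain such as n-butyl, or an amine on the same carbonyl carbon would hold this level remains open. So does whether ethyl on the aromatic nitrogen would stay within the scatter alongside isopropyl.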